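The source may hold more compounds than are shown below. What is called first, only, known or untested is meant among the compounds shown, and "the series" means these compounds.

Compound 1 `COc1cc2c(Oc3ccc(NC(=O)c4cc(-c5ccccc5)nc5ccccc45)cc3F)ccnc2cc1OCCCN1CCCCC1` is the starting point of this small set. In a functional assay on HT-29 cells (Homo sapiens) for cytotoxicity, read by MTT assay, with a stated time of 72 h (a higher number here means a weaker inhibitor, a lower number a stronger inhibitor), compound 1 gives 530 nM. Compound 2 `COc1cc2c(Oc3ccc(NC(=O)c4cc(-c5cccc(Cl)c5)nc5ccccc45)cc3F)ccnc2cc1OCCCN1CCCCC1` carries one change relative to compound 1, namely (chloro in place of hydrogen on an aromatic carbon). In this assay compound 2 gives 62 nM, and the step of an 8.5-fold lower number from compound 1 to compound 2 (0.93 log units; beyond the scatter) shows how much that single change gained.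

Compound 3 `COc1cc2c(Oc3ccc(NC(=O)c4cc(-c5ccccc5)nc5ccc(F)cc45)cc3F)ccnc2cc1OCCCN1CCCC1` has a different core; the difference between the core of compound 3 and the core of compound 1 is not broken down here. In this assay compound 3 gives 160 nM, which places it between the other two measured compounds.

Compound 4 `COc1cc2c(Oc3ccc(NC(=O)c4cc(-c5cccc(Cl)c5)nc5ccc(F)cc45)cc3F)ccnc2cc1OCCCN1CCCC1` has not yet been measured. It relates to compound 3 exactly as compound 2 relates to compound 1: the change is chloro in place of hydrogen on an aromatic carbon, and it sits at the same place in both pairs, so it is the same change made on a second core. Among these compounds this change appears twice, once measured and once not.

The expectation for compound 4 rests on compound 1 and compound 2, where the change produced an 8.5-fold lower number from compound 1 to compound 2 (0.93 log units; beyond the scatter). On these data alone, because the step of an 8.5-fold lower number from compound 1 to compound 2 (0.93 log units; beyond the scatter) was clear and on a closely related core, a step of roughly a 6.4-fold lower number from compound 3 to compound 4 (0.81 log units; beyond the scatter) is expected from compound 3 to compound 4, though how far one core carries over to another is untested here. Compound 4 is therefore estimated at 25 nM, with a plausible range from 8 nM to 70 nM.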

Compound 4, half-maximal inhibitory concentration: 670 nM
The estimate for compound 4 lay 27-fold (1.43 log units) below the measured number; measured number outside the range, above it.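

In this assay, going from phenyl to 3-chlorophenyl on the core of compound 3 gives a 4.2-fold higher number from compound 3 to compound 4 (0.62 log units; beyond the scatter), so the same small change that made the number lower on the first core makes it higher on the second. Set side by side, the two steps point in opposite directions, and the gap between them is larger than chance variation between repeated measurements would explain: the same change on two cores in this assay, an 8.5-fold lower number (0.93 log units; beyond the scatter) from compound 1 to compound 2 and a 4.2-fold higher number (0.62 log units; beyond the scatter) from compound 3 to compound 4, 36-fold (1.55 log units) apart, beyond the scatter of two such steps This shows that, in this series, the result of adding this chloro on one core cannot simply be carried over to another, even a closely related one, but it does not show why the direction flips, and with only two pairs it cannot tell which core is the more typical.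

The compounds shown leave open which part of the difference between the core of compound 1 and the core of compound 3 goes with the reversal, as the two cores are compared here only as wholes. Also open, on these data alone, is whether a bromo or a methyl group in place of the chloro, at the same place on the ring, would follow the first pair, the second pair or neither.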